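This account rests on a few compounds, and the source may have more. Where it says the series, first, only, none or still open, it means among the compounds named here.

Measured so far, in a functional assay on PC-3 cells (Homo sapiens) for inhibition, read by MTT assay, with a stated time of 24 h; on this read-out higher numbers stand for weaker inhibition and lower numbers for stronger inhibition:
compound 1 `CCCc1cc2ccccc2nc1-c1cc(-c2ccccc2)no1`: 51300 nM
compound 2 `CCCCCc1cc2ccccc2nc1-c1cc(-c2ccccc2)no1`: > 100000 nM, a limit of the assay.

For the measured compounds named here, compound 1 holds the only numerical value in this set. The step of an at least 1.9-fold higher number from compound 1 to compound 2 (0.28 log units; that floor lies within the scatter) comes from lengthening the chain and runs into (the limit of > 100000 nM in this assay, at which 1 of the 2 values shown sits). Compound 3 `CCCc1cc2ccccc2nc1-c1cc(-c2ccc(C(F)(F)F)cc2)no1` differs from compound 1 by trifluoromethyl in place of hydrogen on an aromatic carbon. No measured step touches substitution on that six-membered ring, so the one step shown gives no guidance on direction or size here. Without precedent, no shift beyond the scatter is expected, and the step of a 1.0-fold lower number from compound 1 to compound 3 (0.01 log units; within the scatter) is an estimate resting on compound 1 alone. Compound 3 is accordingly expected at 50000 nM, range 15000 nM to 150000 nM.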

Compound 3, half-maximal inhibitory concentration: 33800 nM
The estimate for compound 3 lay 1.5-fold (0.17 log units) above the measured number; the range from low to high includes it.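

In this assay, trifluoromethyl on an aromatic carbon of the six-membered aromatic ring of carbon only, para to a large group, gives a 1.5-fold lower number from compound 1 to compound 3 (0.18 log units; within the scatter). For the compounds shown here, this is the first reading on that ring, and a group of this size there produces no shift beyond the scatter. No measured property among the compounds shown bears on this step.

On these data alone, whether an amine or a carboxylic acid at the same place would move the number beyond the scatter stays open. Also open, as far as these compounds go, is how trifluoromethyl would behave with the longer chain of compound 2, whose value is a limit.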